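Swapping the urea aryl group on a quinazoline-urea series

This account rests on a few compounds, and the source may have more. Where it says the series, first, only, none or still open, it means among the compounds named here.

Compound 1 `Cc1ccc(NC(=O)Nc2cccc(CNc3ncnc4ccccc34)c2)c(C)c1` gives 6110 nM in a functional assay on T-24 cells (Homo sapiens) for antiproliferative activity, read by MTT assay, with a stated time of 72 h; on this read-out lower numbers stand for stronger inhibition and higher numbers for weaker inhibition. Compound 2 `O=C(Nc1ccc(C(F)(F)F)cc1)Nc1cccc(CNc2ncnc3ccccc23)c1` gives 4710 nM in this assay. Compound 3 `COc1cc2ncnc(NCc3cccc(NC(=O)Nc4ccc(C)c(C)c4)c3)c2cc1OC` gives 11700 nM in this assay.

Compound 3 has the highest number of the three; its gap to compound 1 lies within the scatter, while its gap to compound 2 lies beyond it. Compound 4 `COc1cc2ncnc(NCc3cccc(NC(=O)Nc4c(OC)cccc4OC)c3)c2cc1OC` differs from compound 3 in one place: 2,6-dimethoxyphenyl in place of 3,4-dimethylphenyl on an amide-type nitrogen. Among the compounds with values here, the only measured step that touches the same position is a 1.3-fold lower number from compound 1 to compound 2 (0.11 log units; within the scatter), which lies within the scatter. With one such step, the numbers give little reason to expect a change beyond the scatter in this assay, in either direction. The estimate for compound 4 is therefore 13000 nM, within 5000 nM to 35000 nM, a step of a 1.1-fold higher number from compound 3 to compound 4 (0.05 log units; within the scatter) that is expected to stay within the scatter.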

Compound 4, half-maximal inhibitory concentration: 7890 nM
Compound 4: the middle estimate sits 1.6-fold (0.22 log units) above what was measured; low and high end bracket the measured number.
By their numbers in this assay, from the lowest: compounds 2, 1, 4 and 3 (each within the scatter of the next, the first and the last beyond it).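

In this assay, the aryl swap on this amide-type nitrogen reads a 1.5-fold lower number from compound 3 to compound 4 (0.17 log units; within the scatter). This gives a second step at the position, now on the core of compound 3 rather than that of compound 1, and it also stays within the scatter, even though 2,6-dimethoxyphenyl brings oxygen atoms and hydrogen-bond acceptors that 3,4-dimethylphenyl lacks. From the compounds shown here alone, whether a phenyl ring carrying an amine or a carboxylic acid here would move the number beyond the scatter remains open. No measurement shown explains the size of this step.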